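Branched acyclic substituent replacing pyrrolidine on the triazolo core

The source may hold more compounds than are shown below. What is called first, only, known or untested is meant among the compounds shown, and "the series" means these compounds.

Measured so far in an in vitro assay on 293-EBNA cells for binding affinity to corticotropin-releasing factor receptor 1 (Homo sapiens); a higher number here means a weaker inhibitor, a lower number a stronger inhibitor:
compound 1 `CCC(COC)Nc1nc(C)nc2c1nnn2-c1c(C)cc(C)cc1C` gives 59.4 nM
compound 2 `Cc1nc(N2CCCC2)c2nnn(-c3ccc(C(C)C)cc3Br)c2n1` gives 194 nM
compound 3 `CCCC(CC)Nc1nc(C)nc2c1ncn2-c1ccc(C(C)C)cc1Br` gives 4.4 nM

Compound 2 has the highest number of the three in this assay; compound 1 is nearest, with a lower number beyond the scatter, and compound 3 lies furthest away, lower still. Among the compounds with values here, compound 2 is the only member carrying a cyclic amine at the position in question, whereas compounds 1 and 3 both carry a branched acyclic chain there, and both of them sit well below compound 2. Compound 3 shares the bromo- and propan-2-yl-bearing aryl group with compound 2, while its core differs, so the comparison is not a clean one.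

Compound 4 `CCC(CC)Oc1nc(C)nc2c1nnn2-c1ccc(C(C)C)cc1Br` is not yet measured. It differs from compound 2 as follows:
(pentan-3-yl)oxy in place of pyrrolidin-1-yl on an aromatic carbon
The change thus swaps the ring for an open branched chain attached through oxygen, keeping the aryl group of compound 2.

Given that both branched acyclic analogues, compound 1 at 59.4 nM and compound 3 at 4.4 nM, sit below compound 2, a move to a lower number beyond the scatter is expected, estimated as a 9.7-fold lower number from compound 2 to compound 4 (0.99 log units; beyond the scatter). Compound 4 is expected to give about 20 nM in this assay, within a range of 5 nM to 80 nM.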

Compound 4, inhibition constant: 1.9 nM
The estimate for compound 4 lay 11-fold (1.02 log units) above the measured number, outside the stated range (below it).
By their numbers in this assay, from the lowest: compound 4; then compound 3; then compound 1; then compound 2.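

In this assay, replacing pyrrolidin-1-yl with (pentan-3-yl)oxy on the aromatic carbon next to the ring nitrogen gives a 100-fold lower number from compound 2 to compound 4 (2.01 log units; beyond the scatter), a large step with the aryl group and the shared core unchanged. Within the data shown here, this is the first comparison in which only this position differs, and it shows that the group carried here can by itself move the number well beyond the scatter; the earlier compounds differed from one another in more than one place and could not show this. No supporting measurement is available to explain the size of this step.

Going by these compounds, the step combines two changes, opening the ring and replacing the attached nitrogen with oxygen, so the share of each remains open; a pentan-3-ylamino or a cyclopentyloxy group at this carbon, with the aryl group and core of compound 4, would separate them. Also open, on these data alone, is how much the chain itself matters, for instance whether a propan-2-yloxy or a heptan-4-yloxy group would stay close to compound 4 at 1.9 nM.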